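Moving the chlorine on the hydrazide phenyl ring

A few compounds are considered here, and "the series" means these few. Any claim that something is new, unique, unknown or untested is made for them only; others in the source may bear on it.

Compound 1 `O=C(NNc1ccccc1Cl)c1cccc(NS(=O)(=O)c2cnc(O)nc2O)c1` and compound 2 `O=C(NNc1cccc(Cl)c1)c1cccc(NS(=O)(=O)c2cnc(O)nc2O)c1` share one core, while compound 3 `O=C(NNc1ccccc1Cl)c1ccccc1NS(=O)(=O)c1cnc(O)nc1O` and the unmeasured compound 4 `O=C(NNc1cccc(Cl)c1)c1ccccc1NS(=O)(=O)c1cnc(O)nc1O` share another; how the two cores differ is not broken down here. In a functional assay on OVCAR-3 cells (Homo sapiens) for antiproliferative activity, read by MTT assay, with a stated time of 24 h (on this read-out lower numbers stand for stronger inhibition and higher numbers for weaker inhibition), compound 1 gives 3350 nM, compound 2 gives 8040 nM and compound 3 gives 14100 nM. The change 3-chlorophenyl in place of 2-chlorophenyl on an amine nitrogen brought a 2.4-fold higher number from compound 1 to compound 2 (0.38 log units; beyond the scatter). The same change, (3-chlorophenyl in place of 2-chlorophenyl on an amine nitrogen), now takes compound 3 to compound 4. Going by the values given here, since compound 3 already holds the highest number of the three, a step of like direction and size is expected, a 2.1-fold higher number from compound 3 to compound 4 (0.33 log units; beyond the scatter), because the single earlier instance showed a 2.4-fold higher number from compound 1 to compound 2 (0.38 log units; beyond the scatter). On this basis compound 4 is estimated in this assay at 30000 nM, with a likely span from 12000 nM to 75000 nM.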

Compound 4, half-maximal inhibitory concentration: 5520 nM
Beside the measured number, compound 4's estimate is 5.4-fold (0.74 log units) above it; the measured number lies below the stated range.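

In this assay, 3-chlorophenyl in place of 2-chlorophenyl on the amine nitrogen gave the opposite direction on the second core, with a 2.6-fold lower number from compound 3 to compound 4 (0.41 log units; beyond the scatter). The change therefore did not carry over from one core to the other in direction, and the gap between the two steps is larger than scatter alone would give: the same change on two cores in this assay, a 2.4-fold higher number (0.38 log units; beyond the scatter) from compound 1 to compound 2 and a 2.6-fold lower number (0.41 log units; beyond the scatter) from compound 3 to compound 4, 6.1-fold (0.79 log units) apart, beyond the scatter of two such steps. This shows that, among these four compounds, the step on one core does not predict the step on the other, but with one pair per core it does not show why the cores differ or how the change would behave on a further core.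

The compounds shown leave open whether this reversal is particular to chlorine. A fluorine, a methyl or a methoxy group in its place might follow the same course or a different one.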